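A few compounds are considered here, and "the series" means these few. Any claim that something is new, unique, unknown or untested is made for them only; others in the source may bear on it.

Working notes on the series. Compound 1 `N#Cc1ccccc1COc1ccc(-c2cc(CN3CCN(Cc4ccc(C(F)(F)F)cc4)CC3)no2)cc1` carries a 2-cyanophenyl on a saturated chain carbon bound to an oxygen on an aromatic ring; compound 2 `N#Cc1cccc(COc2ccc(-c3cc(CN4CCN(Cc5ccc(C(F)(F)F)cc5)CC4)no3)cc2)c1` and compound 3 `COc1cccc(COc2ccc(-c3cc(CN4CCN(Cc5ccc(C(F)(F)F)cc5)CC4)no3)cc2)c1` keep the shared core and vary that aryl group. In a functional assay on Huh-7 cells (Homo sapiens) for antiproliferative activity, read by sulforhodamine B assay, with a stated time of 72 h (on this read-out higher numbers stand for weaker inhibition and lower numbers for stronger inhibition), compound 1 gives 5000 nM, the highest of the three numbers. Compound 2 gives 100 nM, and compound 3 gives 800 nM. The steps are a 50-fold lower number from compound 1 to compound 2 (1.70 log units; beyond the scatter), a 6.3-fold lower number from compound 1 to compound 3 (0.80 log units; beyond the scatter) and an 8.0-fold higher number from compound 2 to compound 3 (0.90 log units; beyond the scatter).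

Compound 4 `COc1cc(COc2ccc(-c3cc(CN4CCN(Cc5ccc(C(F)(F)F)cc5)CC4)no3)cc2)cc(OC)c1OC` is not yet measured. Relative to compound 1 the change is 3,4,5-trimethoxyphenyl in place of 2-cyanophenyl on a saturated chain carbon bound to an oxygen on an aromatic ring. The step that bears most directly on it is a 6.3-fold lower number from compound 1 to compound 3 (0.80 log units; beyond the scatter), since compound 3 already carries a methoxy on that aryl group and compound 4 carries three. Going by the values given here, the step of a 50-fold lower number from compound 1 to compound 2 (1.70 log units; beyond the scatter) shows that moving away from the 2-cyanophenyl of compound 1 can give a large drop, but no measured compound carries more than one methoxy, so the added two cannot be priced. Expected: a modest-to-large lowering, a 10-fold lower number from compound 1 to compound 4 (1.00 log units; beyond the scatter), beyond the scatter. Compound 4 is therefore estimated at 500 nM, with a range of 100 nM to 2500 nM.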

Compound 4, half-maximal inhibitory concentration: 500 nM
Compound 4: middle estimate and measured number agree at the digits printed, and the stated range covers the measured number.
By their numbers in this assay, from the lowest: compound 2; then compounds 4 and 3 (each within the scatter of the next); then compound 1.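

At this position, the further methoxy groups of the 3,4,5-trimethoxyphenyl add nothing that can be read in this assay: a 1.6-fold lower number from compound 3 to compound 4 (0.20 log units; within the scatter), so the 3-methoxyphenyl and the 3,4,5-trimethoxyphenyl cannot be told apart here, while a 10-fold lower number from compound 1 to compound 4 (1.00 log units; beyond the scatter) shows a second methoxy-bearing aryl group clear of the 2-cyanophenyl. The 3-cyanophenyl remains separate from this methoxy pair, with a 5.0-fold higher number from compound 2 to compound 4 (0.70 log units; beyond the scatter) adding to the earlier gap to compound 3, so compound 2 keeps the lowest number, with its steps to all three other compounds beyond the scatter. No measurement bearing on the reason for these steps is available, for either the nitrile or the methoxy groups.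

The compounds shown leave open whether any aryl group on this saturated chain carbon can go below the number of compound 2, for instance a phenyl carrying an amine or a carboxylic acid in place of the cyano. They also leave open whether a longer chain between the aryl group and the oxygen would keep the gap between the 3-cyanophenyl and the 2-cyanophenyl.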